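Swapping fluoro for methoxy on compound 3's aryl ring

This account rests on a few compounds, and the source may have more. Where it says the series, first, only, none or still open, it means among the compounds named here.

Of the compounds shown here, three built on one shared core have been tested in a functional assay on the whole organism (strain Wistar albino) for inhibition, with Rattus norvegicus as the target, read by paw edema, with stated times of 1 h and 2 h, at a dose of 40 mg/kg by the oral route; on this read-out higher numbers stand for more inhibition at the one dose given (going by the name of the read-out) and lower numbers for less inhibition. Compound 1 `Cc1nc(-c2ccc(Cl)cc2)sc1C1SCC(=O)N1c1ccc(F)c(Cl)c1` gives 45.2% in this assay. Compound 2 `Cc1ccc(N2C(=O)CSC2c2sc(Cc3ccc(Cl)cc3)nc2C)cc1` gives 61.4%. Compound 3 `Cc1nc(-c2ccc(Cl)cc2)sc1C1SCC(=O)N1c1ccc(F)cc1` gives 63.9%, the highest of the three numbers, though compound 2 lies within the scatter of it, so the two cannot be ranked; only compound 1 sits clearly lower. Among the compounds with values here, the one single-point step measured so far is a number 18.7 percentage points higher from compound 1 to compound 3 (beyond the scatter), a modest gain on removing a chloro from the ring attached to the amide nitrogen.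

Compound 4 `COc1ccc(N2C(=O)CSC2c2sc(-c3ccc(Cl)cc3)nc2C)cc1` differs from compound 3 by one change: methoxy in place of fluoro on an aromatic carbon. Within the data shown here, the change sits on the same ring as the earlier step, but no measured pair shows what exchanging fluoro for methoxy does here, and the step from compound 1 to compound 3 concerns a different group, so it guides only loosely. With nothing pointing clearly up or down, the expectation is a step no larger than the scatter, a number 1.9 percentage points lower from compound 3 to compound 4 (within the scatter). Compound 4 is therefore estimated to give 62% in this assay, with a likely range from 48% to 76%.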

Compound 4, a percentage reported as inhibition, in the whole organism at one dose (the size of the read-out at that dose, not a potency): 80.7%
Compound 4: middle estimate off by 18.7 percentage points, on the low side; measured number outside the range, above it.
By their numbers in this assay, from the lowest: compound 1; then compounds 2 and 3 (each within the scatter of the next); then compound 4.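

In this assay, the step from fluoro to methoxy is a number 16.8 percentage points higher from compound 3 to compound 4 (beyond the scatter), so the group at this position, para to a large group, clearly matters for the read-out. The earlier pair showed only that taking a chloro off this ring raised the number, whereas this step shows that replacing the fluoro, with methoxy bringing one more heavy atom and a hydrogen-bond acceptor, can raise it further, and the full change of 4-methoxyphenyl for 3-chloro-4-fluorophenyl on the ring nitrogen is a number 35.5 percentage points higher from compound 1 to compound 4 (beyond the scatter), a large step made by altering this one ring alone. Nothing measured here gives a reason for the rise, so the numbers record the effect without explaining it.

The compounds shown leave open whether the gain is particular to methoxy, since a hydroxy, an ethoxy or a dimethylamino group at the same position could give a lower, similar or higher number. They also leave open whether methoxy would give the same gain on the other compounds in the series, such as one carrying the benzyl group of compound 2.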